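From 3-cyanophenyl to 2-chloropyridin-3-yl

The source may report more compounds than this note shows. Statements on the series, on what has been measured and on what is new or still open speak of the compounds shown alone.

Results in a functional assay on A549 cells (Homo sapiens) for cytotoxicity, read by MTT assay, with a stated time of 24 h (a higher number here means a weaker inhibitor, a lower number a stronger inhibitor), so far

- compound 1 `COc1ccc(/C=C\C(=O)O)c(OCc2cn(-c3ccc(NC(=O)c4ccccc4)cc3)nn2)c1CC=C(C)C` gives 42700 nM
- compound 2 `COc1ccc(/C=C\C(=O)O)c(OCc2cn(-c3cccc(C#N)c3)nn2)c1CC=C(C)C` gives "not determined" (no result reported)
- compound 3 `COc1ccc(/C=C\C(=O)O)c(OCc2cn(-c3ccccc3C(=O)N3CCC(O)C3)nn2)c1CC=C(C)C` gives "not determined" (no result reported)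

Compound 2 has no single number in this assay and so cannot be placed on the scale. Compound 3 is in the same position, and only compound 1 provides a figure (42700 nM). Compound 4 `COc1ccc(/C=C\C(=O)O)c(OCc2cn(-c3cccnc3Cl)nn2)c1CC=C(C)C` has not yet been measured. It carries 2-chloropyridin-3-yl in place of 3-cyanophenyl on an aromatic nitrogen and otherwise keeps the core of compound 2. Within the data shown here, with no number for compound 2, the size of this step cannot be read from the data, and no measured step offers a guide. Among the measured compounds shown here, the only anchor is compound 1 (42700 nM), so compound 4 is expected to fall in that same weak region, with no shift in either direction beyond the scatter. For compound 4 the estimated value is about 45000 nM with an expected range from 15000 nM to 120000 nM in this series.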

Compound 4, half-maximal inhibitory concentration: 5600 nM
The estimate for compound 4 lay 8.0-fold (0.91 log units) above the measured number, outside the stated range (below it).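

In this assay, among these compounds, compound 4 gives 5600 nM, but compound 2 has no single number there, so no step between compound 2 and compound 4 can be read. The compounds shown leave open whether replacing 3-cyanophenyl with 2-chloropyridin-3-yl changes the result at all. No supporting evidence bears on this result.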